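This account rests on a few compounds, and the source may have more. Where it says the series, first, only, none or still open, it means among the compounds named here.

Measured so far:
- compound 1, `COC(=O)/C=C/c1cccc(N(Cc2ccc(/C=C/c3cccc(C(F)(F)F)c3)cc2)C(=O)C(C)C)c1` — 267 nM in an assay on isolated protein with Bile acid receptor (Homo sapiens) as the target; a lower number here means that less compound is needed, a higher number that more compound is needed for the effect
- compound 2, `COC(=O)/C=C/c1cccc(N(Cc2ccc(-c3ccc(F)c(F)c3)cc2)C(=O)C2CCCCC2)c1` — 72 nM
- compound 3, `COC(=O)/C=C/c1cccc(N(Cc2ccc(-c3c(OC)cccc3OC)cc2)C(=O)C(C)C)c1` — 95 nM

Compound 2 gives the lowest of the three numbers in this assay, though its distance to compound 3 is within the scatter; only the gap to compound 1 is beyond it. Going by the values given here, the one step between measured compounds that differ in a single place, a 2.8-fold lower number from compound 1 to compound 3 (0.45 log units; beyond the scatter), swaps one aromatic substituent for another on the same aromatic carbon and gave a modest gain.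

Compound 4, `COC(=O)/C=C/c1cccc(N(Cc2ccc(C(C)(C)C)cc2)C(=O)C2CCCCC2)c1`, is the next case. Its difference from compound 2 is tert-butyl in place of 3,4-difluorophenyl on an aromatic carbon: a tert-butyl group, with no ring, stands where the 3,4-difluorophenyl ring stood, para to a large group. Among the compounds with values here, no measured step covers a ring being replaced by a non-ring group at this position, so the step from compound 1 to compound 3 bears on it only in showing that this position is sensitive. Removing the ring is expected to cost, with the number for compound 4 estimated as a 3.5-fold higher number from compound 2 to compound 4 (0.54 log units; beyond the scatter). Compound 4 is therefore estimated at 250 nM, within a range of 80 nM to 800 nM.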

Compound 4, half-maximal effective concentration: > 1000 nM
Compound 4 gave a limit, no number (the forecaster's own chance of this, stated with the estimate: 5%); at least 4.0-fold (0.60 log units) between middle value and limit.
By their numbers in this assay, from the lowest: compounds 2 and 3 (each within the scatter of the next); then compound 1. At a limit, above all of these: compound 4.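

In this assay compound 4 reads > 1000 nM, which is a limit of the assay and not a number. With an at least 13-fold higher number from compound 2 to compound 4 (1.14 log units; beyond the scatter), this position now has a step in which the aromatic ring leaves and a group with no ring enters, and that step is large, whereas a 2.8-fold lower number from compound 1 to compound 3 (0.45 log units; beyond the scatter), with an aromatic ring present on both sides, is modest. Of the compounds shown, the three with a further aromatic ring at this position give numbers, and only the tert-butyl compound reaches the limit: the limit of > 1000 nM in this assay, at which 1 of the 4 values shown sits.

This single step changes the ring and the heavy-atom count together, so the shown compounds do not tell which of the two matters. As far as these compounds go, whether a saturated cyclohexyl ring, an unsubstituted phenyl or a longer alkyl chain at this position restores a measurable number remains open.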